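Removing a Chloro Group from a Cytotoxicity Scaffold

A few compounds are considered here, and "the series" means these few. Any claim that something is new, unique, unknown or untested is made for them only; others in the source may bear on it.

Compound 1 `COc1ccc(C2=C(c3cc(OC)c(OC)c(OC)c3)C(=O)C(OC(C)=O)C2)cc1Cl` was tested in an ADME assay on PA-1 cells (Homo sapiens) for cytotoxicity, read by MTT assay, with a stated time of 72 h; on this read-out higher numbers stand for weaker inhibition and lower numbers for stronger inhibition. In this assay compound 1 gives > 100 ug/mL, which is a limit of the assay rather than a number. Compound 2 `COc1ccc(C2=C(c3cc(OC)c(OC)c(OC)c3)CC(O)C2=O)cc1[N+](=O)[O-]` also gives > 100 ug/mL, again a limit. Among the compounds with values here, both results sit at the limit of > 100 ug/mL in this assay, at which 2 of the 2 values shown sit, so no measured step can be sized. Compound 3 `COc1ccc(C2=C(c3cc(OC)c(OC)c(OC)c3)C(=O)C(OC(C)=O)C2)cc1` differs from compound 1 by hydrogen in place of chloro on an aromatic carbon. With both measured compounds stopping at the limit, no step beyond the scatter is expected in this assay. The step is estimated as a step that the limit leaves unreadable from compound 1 to compound 3. Compound 3 is expected to give 150 ug/mL, within a range of 60 ug/mL to 400 ug/mL.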

Compound 3, half-maximal inhibitory concentration: < 1 ug/mL
Compound 3: only a limit was reported; the forecaster's own chance of this, stated with the estimate: 80%; middle value at least 150-fold (2.17 log units) away from the limit.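

In this assay, hydrogen in place of chloro on the aromatic carbon ortho to a methoxy group gives an at least 100-fold lower number from compound 1 to compound 3 (2.00 log units; beyond the scatter), so this one position can separate a compound with strong inhibition from one without measurable inhibition. The value for compound 3 is a limit: the limit of < 1 ug/mL in this assay, at which 1 of the 3 values shown sits. The value for compound 1 is also a limit: the limit of > 100 ug/mL in this assay, at which 2 of the 3 values shown sit.

The full size of the step cannot be read from two limits. As far as these compounds go, whether a fluoro, methyl or amino group at this carbon would behave like hydrogen or like chloro remains open.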